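A few compounds are considered here, and "the series" means these few. Any claim that something is new, unique, unknown or untested is made for them only; others in the source may bear on it.

Three compounds have been measured in a functional assay on CCRF-CEM cells (Homo sapiens) for inhibition, read by MTT assay, with a stated time of 72 h; on this read-out lower numbers stand for stronger inhibition and higher numbers for weaker inhibition:

- Compound 1 `COc1cc(NC(C)CCCNC(=O)Nc2cccc(F)c2)c2ncccc2c1`: 21000 nM
- Compound 2 `COc1cc(NC(C)CCCNC(=O)NNC(=O)Nc2ccc(F)cc2)c2ncccc2c1`: 118000 nM
- Compound 3 `COc1cc(NC(C)CCCNC(=O)Nc2cc(C(F)(F)F)cc(C(F)(F)F)c2)c2ncccc2c1`: 4100 nM

Compound 2 gives the highest number of the three and is the weakest inhibitor among them. Compound 4 `COc1cc(NC(C)CCCNC(=O)Nc2ccc(C(F)(F)F)cc2)c2ncccc2c1`, not yet measured, differs from it in one place: 4-(trifluoromethyl)phenyl in place of ((4-fluorophenyl)carbamoyl)amino on an amide-type nitrogen. In words, 4-(trifluoromethyl)phenyl stands in place of ((4-fluorophenyl)carbamoyl)amino on an amide-type nitrogen.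

Within the data shown here, only one measured step bears directly on this change: a 5.6-fold higher number from compound 1 to compound 2 (0.75 log units; beyond the scatter). That modest step lies beyond the scatter and brings in the group that compound 4 lacks, although the aryl group in compound 1 differs from the one entering here. Compound 3 , which also carries trifluoromethyl groups, gives 4100 nM. A lower number is therefore expected, somewhat larger in size than the measured step. The expected change is a 12-fold lower number from compound 2 to compound 4 (1.09 log units; beyond the scatter). For compound 4 the estimate is 9500 nM, with an expected range from 3500 nM to 26000 nM.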

Compound 4, half-maximal inhibitory concentration: 14000 nM
Compound 4: middle estimate off by 1.5-fold (0.17 log units), on the low side, within the range that was stated.
By their numbers in this assay, from the lowest: compound 3; then compounds 4 and 1 (each within the scatter of the next); then compound 2.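

In this assay, putting 4-(trifluoromethyl)phenyl in place of ((4-fluorophenyl)carbamoyl)amino on the amide-type nitrogen gives an 8.4-fold lower number from compound 2 to compound 4 (0.93 log units; beyond the scatter), so the low inhibition of compound 2 is not shared by this simpler aryl urea. Against 3-fluorophenyl at the same place, the change gives a 1.5-fold lower number from compound 1 to compound 4 (0.18 log units; within the scatter), which leaves these two aryl groups indistinguishable on this read-out and sets compound 2 apart from both. No measurement is at hand that accounts for these differences.

On these data alone, what remains open is how 4-fluorophenyl itself would read directly on this nitrogen, so the part played by the inserted carbamoyl-amino unit cannot yet be separated from that of the fluorine's place on the ring. As far as these compounds go, whether a nitrile or a carboxylic acid on the phenyl ring would fit this picture also stays unknown.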